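Dropping one methoxy from compound 2

A few compounds are considered here, and "the series" means these few. Any claim that something is new, unique, unknown or untested is made for them only; others in the source may bear on it.

In a functional assay on THP-1 cells (Homo sapiens) for inhibition, read by sulforhodamine B assay, with a stated time of 48 h, tested at 50 uM (on this read-out higher numbers stand for more inhibition of growth at the one concentration tested and lower numbers for less inhibition of growth), compound 2 (`COc1ccc(/C=C/C(=O)/C=C/c2ccc(OCc3cn(CCCCCOc4cc(=O)oc5ccccc45)nn3)c(OC)c2)cc1OC`) gives 47% and stands second highest of the three measured compounds. Compound 1 (`COc1cc(/C=C/C(=O)/C=C/c2cccc3ccccc23)ccc1OCc1cn(CCCOc2cc(=O)oc3ccccc23)nn1`) gives 71% and compound 3 (`COc1cc(/C=C/C(=O)/C=C/c2ccccc2)ccc1OCc1cn(CCCCOc2cc(=O)oc3ccccc23)nn1`) gives 36%, so compound 2 has compound 1 on its higher side and compound 3 on its lower side, and both gaps are beyond the scatter. Within the data shown here, these three compounds differ in more than one place, so the series offers no measured single-change step to draw on.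

Compound 4 (`COc1ccc(/C=C/C(=O)/C=C/c2ccc(OCc3cn(CCCCCOc4cc(=O)oc5ccccc45)nn3)c(OC)c2)cc1`) departs from compound 2 in one place: hydrogen in place of methoxy on an aromatic carbon (hydrogen in place of methoxy on an aromatic carbon, so that 3,4-dimethoxyphenyl becomes 4-methoxyphenyl). No step beyond the scatter is expected in this assay for this change. The estimated a number 3 percentage points lower from compound 2 to compound 4 (within the scatter) is small and slightly downward, and it rests on compound 2 at 47% as the only close anchor. The estimated value for compound 4 is 44% with 28% to 60% as the expected range.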

Compound 4, percent growth inhibition at one concentration: 39%
The estimate for compound 4 lay 5 percentage points above the measured number; the range from low to high includes it.
By their numbers in this assay, from the lowest: compounds 3, 4 and 2 (each within the scatter of the next, the first and the last beyond it); then compound 1.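

Hydrogen in place of methoxy on an aromatic carbon, ortho to a methoxy group, gives a number 8 percentage points lower from compound 2 to compound 4 (within the scatter) in this assay and is the first single-change step measured in this series. At this position and at this one concentration, the 3,4-dimethoxyphenyl and 4-methoxyphenyl ends therefore cannot be told apart, so this methoxy is not shown to matter for growth inhibition. Nothing available bears on the reason for this result.

Still open, as far as these compounds go, is whether a different group at this position, such as a hydroxyl or an amine, would give a step beyond the scatter. From the compounds shown here alone, the step also rests on one pair, so it remains open whether the same change reads alike on a compound with a shorter linking chain or another aromatic end.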